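Removing One Fluoro From a Difluorophenyl Thioether

A few compounds are considered here, and "the series" means these few. Any claim that something is new, unique, unknown or untested is made for them only; others in the source may bear on it.

Measured compounds:
compound 1, `C#CCNC1CCc2c(SCCc3ccc(F)c(F)c3)cccc21`, in an ADME assay on isolated protein for inhibition of Amine oxidase [flavin-containing] B (Homo sapiens); on this read-out lower numbers stand for stronger inhibition and higher numbers for weaker inhibition "not determined" (no result reported)
compound 2, `C#CCNC1CCc2c(SCc3ccc(F)cc3F)cccc21`, in this assay 1480 nM

Compound 1, `C#CCNC1CCc2c(SCCc3ccc(F)c(F)c3)cccc21`, carries a 3,4-difluorophenyl group joined to the shared core through a two-carbon chain and a sulfur. No number for compound 1 in this assay has been recorded, so compound 1 cannot be placed against compound 2 on the figures shown. Compound 2, `C#CCNC1CCc2c(SCc3ccc(F)cc3F)cccc21`, with a shorter one-carbon chain and a different fluoro pattern, gives 1480 nM in this assay and is the only measured anchor.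

Compound 3, `C#CCNC1CCc2c(SCCc3cccc(F)c3)cccc21`, is reached from compound 1 by the change (hydrogen in place of fluoro on an aromatic carbon). Among the measured compounds shown here, with no measured value for compound 1, no step can be read off for this change, and on the single measured compound no step beyond the usual scatter in this assay is expected in either direction. For compound 3 a value of about 1500 nM is estimated, with a plausible range from 300 nM to 8000 nM, the breadth reflecting that the only measured reference, compound 2, carries a different chain and fluoro pattern.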

Compound 3, half-maximal inhibitory concentration: 7810 nM
Compound 3: the middle estimate sits 5.2-fold (0.72 log units) below what was measured, and the stated range covers the measured number.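

Among the compounds shown here, no step from compound 1 to compound 3 can be read in this assay, where compound 1 is recorded as "not determined" (no result reported) and compound 3 gives 7810 nM. The compounds shown leave open what the change from 3,4-difluorophenyl to 3-fluorophenyl does to inhibition on its own. Nothing shown bears on an explanation for the value of compound 3.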